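Adding a second chlorine to a seizure-protection scaffold

The source may report more compounds than this note shows. Statements on the series, on what has been measured and on what is new or still open speak of the compounds shown alone.

Of the compounds shown here, three sharing one core have been tested in a functional assay on the whole organism with Rattus norvegicus as the target, in the maximal electroshock model, with a stated time of 1 h; a lower number here means that less compound is needed, a higher number that more compound is needed for the effect. Compound 1, with structure `NC(=O)N/N=C/c1ccccc1Cl`, gives 38.8 mg/kg. Compound 2, with structure `NC(=O)N/N=C/c1ccc(Cl)cc1`, gives 18.6 mg/kg, the lowest of the three numbers, so that the least of it is needed for the effect. Compound 3, with structure `NC(=O)N/N=C/c1c(Cl)cccc1Cl`, gives 59 mg/kg.

Compound 1 and compound 2 are built from the same atoms joined differently; how the two cores differ is not broken down here. Compound 3 arises from compound 1 by chloro in place of hydrogen on an aromatic carbon, and this change made a step of a 1.5-fold higher number from compound 1 to compound 3 (0.18 log units; within the scatter), meaning that the second chlorine left the result essentially where it was.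

Compound 4, with structure `NC(=O)N/N=C/c1ccc(Cl)c(Cl)c1`, has not been measured in this assay. It arises from compound 2 by chloro in place of hydrogen on an aromatic carbon. Within the data shown here, this is the same kind of change as the one from compound 1 to compound 3, but the surroundings differ: in compound 3 the new chloro sits ortho to a group of 6 heavy atoms and meta to a chloro group, whereas in compound 4 it sits ortho to a chloro group and meta to a group of 6 heavy atoms.

Among the measured compounds shown here, with only one precedent for this kind of change, the expectation for compound 4 rests on the step of a 1.5-fold higher number from compound 1 to compound 3 (0.18 log units; within the scatter): a step of about a 1.3-fold higher number from compound 2 to compound 4 (0.13 log units; within the scatter) is estimated. Compound 4 is therefore expected to give about 25 mg/kg in this assay, within a range from 12 mg/kg to 50 mg/kg.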

Compound 4, dose for half-maximal effect: 20.2 mg/kg
Compound 4: middle estimate off by 1.2-fold (0.09 log units), on the high side, and the stated range covers the measured number.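

In this assay, adding the chloro to the core of compound 2 made a step of a 1.1-fold higher number from compound 2 to compound 4 (0.04 log units; within the scatter), so here too a second chlorine left the result essentially where it was. Set beside the earlier case, the same change behaved alike on the two cores: the same change on two cores in this assay, a 1.5-fold higher number (0.18 log units; within the scatter) from compound 1 to compound 3 and a 1.1-fold higher number (0.04 log units; within the scatter) from compound 2 to compound 4, 1.4-fold (0.15 log units) apart, within the scatter of two such steps

This shows only that, in these two pairs, the change carried over from one core to the other as a step too small to tell from repeated-measurement noise; it does not show that the change has a real effect of a fixed size, that it would stay this small on a further core, or why the two steps agree, since two pairs are a thin basis and the new chloro sits in a different place in each.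

All the compounds shown carry only chlorine on the ring, so they leave open how a different group on the same aromatic carbon, such as a methoxy group, an amine or a carboxylic acid, would behave. They also leave open whether a third chlorine on the ring would again leave the number unmoved, or whether a longer chain on the shared core would change the picture.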